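Swapping iodo for hydrogen on a small core

The source may report more compounds than this note shows. Statements on the series, on what has been measured and on what is new or still open speak of the compounds shown alone.

In a functional assay on HCT-116 cells (Homo sapiens) for cytotoxicity, with a stated time of 3 days (on this read-out lower numbers stand for stronger inhibition and higher numbers for weaker inhibition), compound 3 (`Cn1c(I)nc2ccccc21`) gives 17500 nM, while compound 2 (`C=Cc1nc2ccccc2n1C`) gives 9500 nM. These two values lie within the scatter of each other. Compound 1 (`Brc1nc2ccccc2[se]1`) gives > 40000 nM, which is a limit of the assay and not a number.

Compound 4 (`Cn1cnc2ccccc21`) has hydrogen in place of iodo on an aromatic carbon. Among the measured compounds shown here, only one measured step bears on this change, and it also alters a group on an aromatic carbon: a 1.8-fold higher number from compound 2 to compound 3 (0.27 log units; within the scatter). No shift beyond the scatter is therefore expected in this assay. The expected change is a 1.0-fold higher number from compound 3 to compound 4 (0.01 log units; within the scatter). For compound 4, the estimated value is 18000 nM, with an expected range from 8000 nM to 40000 nM.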

Compound 4, half-maximal inhibitory concentration: > 40000 nM
Compound 4: only a limit was reported; the forecaster's own chance of this, stated with the estimate: 25%; middle value at least 2.2-fold (0.34 log units) away from the limit.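

Putting hydrogen on this carbon, between two ring nitrogen atoms, gives a step that iodo in place of vinyl did not give in this assay: an at least 2.2-fold higher number from compound 3 to compound 4 (0.35 log units; beyond the scatter). Hydrogen in place of vinyl at the same carbon points the same way, with an at least 4.2-fold higher number from compound 2 to compound 4 (0.62 log units; beyond the scatter), so among compound 2, compound 3 and compound 4, either group on this carbon goes with a lower number than hydrogen. Compound 4 carries a limit of the assay, not a number: the limit of > 40000 nM in this assay, at which 2 of the 4 values shown sit.

Going by these compounds, how far the number of compound 4 truly lies from the others stays open. So does whether an amine or a carboxylic acid on this carbon would keep the numbers of compound 2 and compound 3.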